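The compounds below may be only part of what the source reports. "The series", "measured", "known", "first", "only" and "open" are said of these compounds alone.

Measured in a functional assay on A549 cells (Homo sapiens) for antiproliferative activity, read by MTT assay, with a stated time of 72 h; on this read-out lower numbers stand for stronger inhibition and higher numbers for weaker inhibition:
- Compound 1 `NC1=NC2(CCSCC2)N(OCCCOc2ccc(Cl)c(Cl)c2)C(N)=N1`: 1 nM
- Compound 2 `NC1=NC2(CCOCC2)N(OCCCOc2ccc(Cl)cc2)C(N)=N1`: 360 nM
- Compound 3 `NC1=NC2(CCOCC2)N(OCCCOc2ccc(Cl)cc2Cl)C(N)=N1`: 70 nM

Compound 3 holds the middle place of the three numbers, with a higher number for compound 2 and a lower one for compound 1. The next compound, compound 4 `Cc1ccc(OCCCON2C(N)=NC(N)=NC23CCOCC3)cc1`, has 4-methylphenyl in place of 2,4-dichlorophenyl on the oxygen of the side chain: 4-methylphenyl in place of 2,4-dichlorophenyl on an oxygen on a saturated carbon.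

Going by the values given here, one measured step bears directly on this change: a 5.1-fold lower number from compound 2 to compound 3 (0.71 log units; beyond the scatter), with chloro in place of hydrogen on an aromatic carbon. Compound 4 carries no chloro, so a step of similar modest size is expected in reverse, towards a higher number in this assay. Among the compounds with values here, no measured step covers methyl in place of chloro, which leaves the estimate loose. Compound 1 differs from compound 3 in more than one place and gives no clean guide.

The expected step is a 4.3-fold higher number from compound 3 to compound 4 (0.63 log units; beyond the scatter). For compound 4 the estimated value is 300 nM, with an expected range from 100 nM to 900 nM.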

Compound 4, half-maximal inhibitory concentration: 1060 nM
Estimate against measurement, compound 4: 3.5-fold (0.55 log units) below, and the stated range ends below it.
By their numbers in this assay, from the lowest: compound 1; then compound 3; then compound 2; then compound 4.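

In this assay, the change on the oxygen of the side chain gives a 15-fold higher number from compound 3 to compound 4 (1.18 log units; beyond the scatter), the largest step yet seen among compounds that differ in one place. Methyl in place of chloro on an aromatic carbon, a swap no earlier pair covered, gives a 2.9-fold higher number from compound 2 to compound 4 (0.47 log units; beyond the scatter), so on this series methyl does not match chloro. With a 5.1-fold lower number from compound 2 to compound 3 (0.71 log units; beyond the scatter), the three aryl groups on the shared core now fall in one order, from lowest number to highest: 2,4-dichlorophenyl, the monochloro group of compound 2, then 4-methylphenyl. Nothing available explains this order.

The compounds shown leave open where a plain phenyl or a methoxyphenyl on the same oxygen would fall. They also leave open whether this order holds on the core of compound 1.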